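This account rests on a few compounds, and the source may have more. Where it says the series, first, only, none or still open, it means among the compounds named here.

Within the data shown here, compound 1 `Cc1n[nH]c(C)c1Oc1c(O)cc(O)c2c(=O)cc(-c3ccc(N4CCN(c5ccccc5)CC4)cc3)oc12` is one of three compounds measured in an assay on cells for inhibition of ubiquitin carboxyl-terminal hydrolase 8 (Homo sapiens), read by fluorescence, with a stated time of 30 min; a lower number here means a stronger inhibitor, a higher number a weaker inhibitor. In this assay compound 1 gives 3500 nM; compound 2 `COc1c(O)cc(O)c2c(=O)cc(-c3ccc(N4CCN(C=O)CC4)cc3)oc12` gives 2200 nM, which lies within the scatter of compound 1, while compound 3 `COc1c(O)cc(O)c2c(=O)cc(-c3ccc(N4CCN(C)CC4)cc3)oc12` gives 16500 nM, a number beyond the scatter above compound 1. Among the measured compounds shown here, the only step between measured compounds, a 7.5-fold higher number from compound 2 to compound 3 (0.88 log units; beyond the scatter), concerns methyl in place of formyl on an amine nitrogen in a ring. Compound 4 `Cc1n[nH]c(C)c1Oc1c(O)cc(O)c2c(=O)cc(-c3ccc(N4CCN(c5ccccn5)CC4)cc3)oc12` differs from compound 1 by pyridin-2-yl in place of phenyl on an amine nitrogen in a ring. For the measured compounds named here, no measured pair exchanges one aromatic group for another on that ring nitrogen, so the formyl-to-methyl step bears on this change only loosely. The account therefore expects compound 4 to show a 1.2-fold lower number from compound 1 to compound 4 (0.07 log units; within the scatter), with an estimated value of 3000 nM, ranging from 1200 nM to 8000 nM.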

Compound 4, half-maximal inhibitory concentration: 1200 nM
Compound 4: middle estimate off by 2.5-fold (0.40 log units), on the high side, and the stated range covers the measured number.
By their numbers in this assay, from the lowest: compounds 4, 2 and 1 (each within the scatter of the next, the first and the last beyond it); then compound 3.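

Until now, this ring nitrogen had been compared only between formyl and methyl, and those compounds left open whether one aromatic group could be exchanged for another there. In this assay, pyridin-2-yl in place of phenyl gives a 2.9-fold lower number from compound 1 to compound 4 (0.46 log units; beyond the scatter), a clear step between two groups of equal heavy-atom count, with one ring nitrogen and one hydrogen-bond acceptor entering. No evidence given here accounts for this step. The compounds shown leave open how pyridin-4-yl or pyrimidin-2-yl would compare on this nitrogen, and whether the exchange would have the same effect with a methoxy group in place of the dimethylpyrazolyloxy group.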